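Aryl variation on the piperazine nitrogen at adenosine A3

The source may hold more compounds than are shown below. What is called first, only, known or untested is meant among the compounds shown, and "the series" means these compounds.

Compound 3 `Nc1scc(CN2CCN(c3cc(F)cc(F)c3)CC2)c1C(=O)c1ccc(Cl)cc1` stands second highest of three numbers in an assay on CHO cells for displacement of a labelled ligand from adenosine receptor A3 (Homo sapiens), read by scintillation counting, with a stated time of 120 min, tested at 10 uM (a lower number here means less inhibition, a higher number more inhibition at the concentration tested (going by the name of the read-out)), giving 2%; compound 1 `Nc1scc(CN2CCN(c3cccc(Cl)c3Cl)CC2)c1C(=O)c1ccc(Cl)cc1` gives 0% and compound 2 `Nc1scc(CN2CCN(c3cccc(F)c3)CC2)c1C(=O)c1ccc(Cl)cc1` gives 4%, and all three sit within the scatter of one another. The measured steps are a number 4 percentage points higher from compound 1 to compound 2 (within the scatter), a number 2 percentage points higher from compound 1 to compound 3 (within the scatter) and a number 2 percentage points lower from compound 2 to compound 3 (within the scatter), none beyond the scatter. Compound 4 `Nc1scc(CN2CCN(c3ccc(F)c(Cl)c3)CC2)c1C(=O)c1ccc(Cl)cc1` differs from compound 3 by 3-chloro-4-fluorophenyl in place of 3,5-difluorophenyl on an amine nitrogen in a ring. Within the data shown here, no measured step covers a chlorine entering this ring, yet both aryl exchanges on this nitrogen, a number 4 percentage points higher from compound 1 to compound 2 (within the scatter) and a number 2 percentage points higher from compound 1 to compound 3 (within the scatter), stayed within the scatter, so the expected step is no change at the digits printed from compound 3 to compound 4 (within the scatter), nothing beyond the scatter. Compound 4 is therefore estimated at 2%, ranging from -8% to 12%.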

Compound 4, a percentage reported as inhibition, at one concentration (the size of the read-out at that concentration, not a potency): 0%
The estimate for compound 4 lay 2 percentage points above the measured number; the measured number falls inside the stated range.
By their numbers in this assay, from the lowest: compounds 1, 4, 3 and 2 (each within the scatter of the next).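

With 3-chloro-4-fluorophenyl on the amine nitrogen, chlorine and fluorine now occur on one aryl group, and in this assay the steps read a number 2 percentage points lower from compound 3 to compound 4 (within the scatter) and a number 4 percentage points lower from compound 2 to compound 4 (within the scatter) and no change at the digits printed from compound 1 to compound 4 (within the scatter). The four halogenated phenyl groups shown on this nitrogen therefore cannot be told apart in this read-out. Nothing available explains this result.

On these data alone, whether any group on this nitrogen can raise the number beyond the scatter stays open. A methoxy or a nitrile on the phenyl ring, or a benzyl group in its place, would test this.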